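This account rests on a few compounds, and the source may have more. Where it says the series, first, only, none or still open, it means among the compounds named here.

In an ADME assay on BHK-21 cells (Mesocricetus auratus) for cytotoxicity, read by MTT assay (a lower number here means that less compound is tolerated, a higher number that more compound is tolerated), two compounds sharing one core have been measured. Compound 1 `C/C(=N\O)c1ccc2[nH]c(-c3ccc(Cl)cc3)nc2c1` gives 33000 nM. Compound 2 `C/C(=N\NC(N)=O)c1ccc2[nH]c(-c3ccc(Cl)cc3)nc2c1` is reported only as a limit of the assay, > 100000 nM. This places compound 2 at the limit of > 100000 nM in this assay, at which 1 of the 2 values shown sits.

Compound 3 `C/C(=N\NC(N)=O)c1ccc2[nH]c(-c3ccoc3)nc2c1` differs from compound 2 by one change: furan-3-yl in place of 4-chlorophenyl on an aromatic carbon. Among the measured compounds shown here, the only measured step, an at least 3.0-fold higher number from compound 1 to compound 2 (0.48 log units; beyond the scatter), is at least modest, but it lies at a different place, ureido in place of hydroxy on a double-bonded nitrogen. For the measured compounds named here, no measured step alters the group now being exchanged, so the guidance is weak. The estimated outcome in this assay is no change beyond the scatter, and the expected step is a number no higher from compound 2 to compound 3 (the limit leaves the size open). For compound 3 the estimated value is 100000 nM, with an expected range of 35000 nM to 200000 nM.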

Compound 3, half-maximal cytotoxic concentration: > 100000 nM
Compound 3 was reported as a limit; the forecaster's own chance of this, stated with the estimate: 65%; the middle value lies on the limit itself.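

In this assay compound 2 and compound 3 are both reported as limits, not numbers, so the exchange of 4-chlorophenyl for furan-3-yl yields no readable step: the limit of > 100000 nM in this assay, at which 2 of the 3 values shown sit. The compounds shown leave open how far past that limit each compound lies, and whether this exchange shifts the tolerated concentration at all.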